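Removing the ring substituent in an acylguanidine series

A few compounds are considered here, and "the series" means these few. Any claim that something is new, unique, unknown or untested is made for them only; others in the source may bear on it.

Compounds measured so far:
compound 1 `CCSc1cc(C)c(C(=O)N=C(N)N)cc1S(C)(=O)=O`: 5.9 nM
compound 2 `Cc1cc(N2CCCC(O)C2)c(S(C)(=O)=O)cc1C(=O)N=C(N)N`: 30 nM

In a functional assay for inhibition of sodium/hydrogen exchanger (Oryctolagus cuniculus) (a lower number here means a stronger inhibitor, a higher number a weaker inhibitor), compound 1 gives 5.9 nM and compound 2 gives 30 nM. Among the compounds with values here, compound 2 thus holds the highest of the two numbers; the only step measured is a 5.1-fold higher number from compound 1 to compound 2 (0.71 log units; beyond the scatter), which places the 3-hydroxypiperidin-1-yl group on the side of weaker inhibition relative to the ethylsulfanyl group.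

Compound 3 `Cc1ccc(S(C)(=O)=O)cc1C(=O)N=C(N)N` carries hydrogen in place of 3-hydroxypiperidin-1-yl on an aromatic carbon. Within the data shown here, no measured compound has hydrogen at this aromatic carbon, so the one step known bears on it only indirectly: it shows that the group at this position shifts the number beyond the scatter, in either direction. With the substituent removed, a further rise in this assay, of roughly the size of the known step, seems the more likely outcome, but a return toward compound 1 cannot be excluded. The step of a 2.0-fold higher number from compound 2 to compound 3 (0.30 log units; within the scatter) is therefore the expectation, with wide bounds. Compound 3 is expected at 60 nM (range 15 nM to 300 nM).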

Compound 3, half-maximal inhibitory concentration: 150 nM
For compound 3 the middle estimate is 2.5-fold (0.40 log units) below the measured one, and the stated range covers the measured number.
By their numbers in this assay, from the lowest: compound 1; then compound 2; then compound 3.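

In this assay, a substituent on this aromatic carbon, ortho to a methylsulfonyl group, proves better than none: hydrogen in place of 3-hydroxypiperidin-1-yl gives a 5.0-fold higher number from compound 2 to compound 3 (0.70 log units; beyond the scatter), so the weaker of the two earlier groups still outperforms hydrogen. Hydrogen in place of ethylsulfanyl gives a 25-fold higher number from compound 1 to compound 3 (1.41 log units; beyond the scatter), which sets the full span seen at this position and places the three groups in the order ethylsulfanyl, 3-hydroxypiperidin-1-yl, hydrogen, from lowest number to highest. No measurement at hand explains this order.

Where an unsubstituted piperidin-1-yl, a methoxy group or a propylsulfanyl chain would fall in this order remains open. Also open, as far as these compounds go, is whether the hydroxyl of the 3-hydroxypiperidin-1-yl group contributes to the number for compound 2.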